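The compounds below may be only part of what the source reports. "The series", "measured", "known", "first", "only" and "open" are said of these compounds alone.

Working notes on the series in a functional assay on B16-F10 cells (Mus musculus) for antiproliferative activity, read by MTT assay, with a stated time of 48 h; a higher number here means a weaker inhibitor, a lower number a stronger inhibitor. Compound 1 `COc1ccc(/C=C/c2cc(OC)cc(OC)c2/C=C/C(=O)c2cccc(Cl)c2)cc1` gives 3.3 ug/mL, and compound 2 `COc1ccc(/C=C/c2cc(OC)cc(OC)c2/C=C/C(=O)c2ccc(Cl)cc2)cc1` gives 4.9 ug/mL. Within the data shown here, the two numbers cannot be told apart: the step of a 1.5-fold higher number from compound 1 to compound 2 (0.17 log units; within the scatter) lies within the scatter, so compound 2 stands level with the only other measured compound.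

Compound 3 `COc1ccc(/C=C/c2cc(OC)cc(OC)c2/C=C/C(=O)c2ccc(C)c(C)c2)cc1` keeps the core of compound 2 and differs only in the group on a carbonyl carbon: 3,4-dimethylphenyl in place of 4-chlorophenyl on a carbonyl carbon. In words, 3,4-dimethylphenyl comes in place of 4-chlorophenyl.

Among the measured compounds shown here, one measured step bears on this place, a 1.5-fold higher number from compound 1 to compound 2 (0.17 log units; within the scatter), an exchange of 3-chlorophenyl for 4-chlorophenyl. For the measured compounds named here, it is small, but it compares only two chlorophenyl groups. Going by the values given here, no measured compound carries 3,4-dimethylphenyl, so the data give no direct measure of this exchange and no direction for it. Starting from compound 2 at 4.9 ug/mL, no step beyond the scatter is expected in this assay, though the uncertainty is wider than for the chlorine exchange. The estimated step is a 1.0-fold higher number from compound 2 to compound 3 (0.01 log units; within the scatter). For compound 3 the expected value is 5 ug/mL, with an estimated range of 2.3 ug/mL to 11 ug/mL.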

Compound 3, half-maximal inhibitory concentration: 1.4 ug/mL
Compound 3: the middle estimate sits 3.6-fold (0.55 log units) above what was measured; measured number outside the range, below it.
By their numbers in this assay, from the lowest: compound 3; then compounds 1 and 2 (each within the scatter of the next).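

In this assay the group on the carbonyl carbon now proves able to move the number beyond the scatter, with a 3.5-fold lower number from compound 2 to compound 3 (0.54 log units; beyond the scatter) and a 2.4-fold lower number from compound 1 to compound 3 (0.37 log units; beyond the scatter) running the same way and both modest in size, whereas the exchange between the two chlorophenyl groups stayed within the scatter. The 3,4-dimethylphenyl group, with no chlorine among its atoms, therefore separates compound 3 from both chlorophenyl compounds, and compound 3 has the lowest number of the three. Nothing at hand accounts for this difference, so it stands as a description of the exchange alone.

Going by these compounds, it remains open whether a phenyl group with a single methyl group would give a comparable step or whether both methyl groups are needed. Also open, on these data alone, is how a methoxy group or an amine in place of the methyl groups would read in this assay, and whether the lower number holds beyond these three compounds.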